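Extending the Thioether Chain on a Shared Core

The compounds below may be only part of what the source reports. "The series", "measured", "known", "first", "only" and "open" are said of these compounds alone.

Of the compounds shown here, two built on the same core have been measured in a functional assay on MGC-803 cells (Homo sapiens) for inhibition, read by MTT assay, with a stated time of 72 h; on this read-out lower numbers stand for stronger inhibition and higher numbers for weaker inhibition. Compound 1 `C#CCSc1nc(Nc2ccc(Cl)cc2Cl)c2ccncc2n1` gives 25500 nM in this assay. Compound 2 `CCCSc1nc(Nc2cccc(OC)c2)c2ccncc2n1` gives 1950 nM in this assay, the lower of the two numbers, and the gap to compound 1 lies beyond the scatter of repeated measurements. The two compounds differ in more than one place, so their values cannot be tied to any single change.

Compound 3 `COc1cccc(Nc2nc(SCC3CCCCC3)nc3cnccc23)c1` has not yet been measured. Against compound 2 it differs in one place: cyclohexyl in place of ethyl on a saturated chain carbon bound to a sulfur. Among the compounds with values here, no measured pair shows what this kind of change does, so the direction of the step cannot be read from the numbers so far. The step from compound 2 to compound 3 is expected to be a 1.3-fold lower number from compound 2 to compound 3 (0.11 log units; within the scatter), small and without a clear direction, not beyond the scatter. Compound 3 is therefore estimated at 1500 nM in this assay, with a range from 400 nM to 6000 nM.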

Compound 3, half-maximal inhibitory concentration: 23700 nM
The estimate for compound 3 lay 16-fold (1.20 log units) below the measured number; the whole stated range lies below it.
By their numbers in this assay, from the lowest: compound 2; then compounds 3 and 1 (each within the scatter of the next).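

Within the data shown here, this is the first pair on the shared core that differs in one place, and it shows that the group on the sulfur strongly affects the result in this assay: replacing propyl with cyclohexylmethyl gives a 12-fold higher number from compound 2 to compound 3 (1.08 log units; beyond the scatter). Compounds 1 and 2 differ in more than one place, so they could not reveal this, whereas here the rest of the molecule stays the same and the loss of inhibition can be tied to this single change on a saturated chain carbon bound to a sulfur. No measurement available here explains why this change has such an effect.

A single step cannot separate the presence of the six-membered ring from the addition of more carbon, and a straight heptyl chain on the sulfur would help to tell those two apart. As far as these compounds go, it also remains open how much of the chain can change before inhibition falls, and whether a shorter chain such as methyl, or a propyl chain ending in an amine, would give a lower or higher number.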